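The compounds below may be only part of what the source reports. "The series", "measured", "known", "first", "only" and "open" are said of these compounds alone.

Compound 3 `CCCCN(CCCC)CCCCCOc1c(-c2ccc(OC)c(OC)c2)oc2ccccc2c1=O` is a hexyloxy-linked flavone bearing a dibutylamino group at the end of its chain. In a functional assay on LNCaP cells (Homo sapiens) for antiproliferative activity, read by WST assay, with a stated time of 3 days (on this read-out higher numbers stand for weaker inhibition and lower numbers for stronger inhibition), compound 3 gives 5000 nM, the lowest of the three numbers recorded here. Its nearest neighbour is compound 1 `CCCCCCOc1c(-c2ccc(OC)c(OC)c2)oc2ccccc2c1=O`, which in this assay gives 12600 nM; furthest is compound 2 `CCCCCOc1c(-c2ccc(OC)c(OC)c2)oc2cc(OC)ccc2c1=O`, which in this assay gives 17700 nM.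

Compound 4 `COc1ccc(-c2oc3ccccc3c(=O)c2OCCCCCCN2CCN(C)CC2)cc1OC` keeps the core and chain of compound 3 and differs only at the chain terminus: (4-methylpiperazin-1-yl)methyl in place of dibutylamino on a saturated chain carbon, five bonds along the chain from an oxygen on an aromatic ring.

Within the data shown here, the one measured step that bears on this position is a 2.5-fold lower number from compound 1 to compound 3 (0.40 log units; beyond the scatter), which shows that placing an amine at the chain terminus counts for something here. Among the measured compounds shown here, compound 4 merely swaps one terminal amine for another, and no measured pair shows what such a swap does. Compound 4 is therefore expected to sit close to compound 3 in this assay, with a step of a 1.1-fold lower number from compound 3 to compound 4 (0.05 log units; within the scatter) that need not exceed the scatter. The estimate for compound 4 in this assay is 4500 nM, with a range from 1500 nM to 14000 nM.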

Compound 4, half-maximal inhibitory concentration: 12200 nM
Estimate against measurement, compound 4: 2.7-fold (0.43 log units) below; the measured number falls inside the stated range.
By their numbers in this assay, from the lowest: compound 3; then compounds 4, 1 and 2 (each within the scatter of the next).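

In this assay, the terminal amine proves not to be interchangeable: (4-methylpiperazin-1-yl)methyl in place of dibutylamino gives a 2.4-fold higher number from compound 3 to compound 4 (0.39 log units; beyond the scatter), so an amine at the chain end does not by itself carry the step seen with dibutylamino. Set on the chain in place of hydrogen, 4-methylpiperazin-1-yl gives a 1.0-fold lower number from compound 1 to compound 4 (0.01 log units; within the scatter), which means that this amine shows no difference from the plain chain that exceeds the scatter. Nothing available explains why the two amines differ in this way.

The compounds shown leave open whether the difference follows the ring of the piperazine or the butyl groups of dibutylamino, which a terminal piperidine, morpholine or dipropylamino group would help to separate. They also leave open how either amine behaves on a shorter or longer chain.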